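From 2,4-dimethoxyphenyl to phenyl on a shared core

The source may report more compounds than this note shows. Statements on the series, on what has been measured and on what is new or still open speak of the compounds shown alone.

Measured in a functional assay on BT-474 cells (Homo sapiens) for inhibition, read by fluorescence, with a stated time of 72 h; a lower number here means a stronger inhibitor of growth, a higher number a weaker inhibitor of growth:
Compound 1 `COc1ccc(Nc2nc(N[C@H]3CC[C@H](N)CC3)nc3c2ncn3CCC(C)C)c(OC)c1`: 7900 nM
Compound 2 `CC(C)=CCn1cnc2c(Nc3cccc(Cl)c3)nc(N[C@H]3CC[C@H](N)CC3)nc21`: 7000 nM
Compound 3 `CCCCCCn1cnc2c(Nc3ccc(O)cc3)nc(N[C@H]3CC[C@H](N)CC3)nc21`: 7700 nM

Compound 1 stands level with the other two compounds, since its value of 7900 nM lies within the usual scatter of both. With differences this small, the three numbers cannot be put in a meaningful order.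

The next compound to be tested is compound 4 `CC(C)CCn1cnc2c(Nc3ccccc3)nc(N[C@H]3CC[C@H](N)CC3)nc21`. It differs from compound 1 in one place, with phenyl in place of 2,4-dimethoxyphenyl on a nitrogen on an aromatic ring.

Among the compounds with values here, no two measured compounds differ in one place only, so this change has no direct precedent here, and any forecast is indirect. Compound 2 at 7000 nM and compound 3 at 7700 nM carry other groups on that nitrogen and other chains, yet their values stay within the scatter of compound 1. That gives no reason to expect a real shift in this assay in either direction, though three compounds are thin evidence. The expected change is a 1.1-fold lower number from compound 1 to compound 4 (0.05 log units; within the scatter), a step not expected to go beyond the scatter. The estimate for compound 4 is 7000 nM, with an expected range from 2500 nM to 18000 nM.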

Compound 4, concentration for 50% growth inhibition: 6400 nM
For compound 4 the middle estimate is 1.1-fold (0.04 log units) above the measured one; the measured number falls inside the stated range.
By their numbers in this assay, from the lowest: compounds 4, 2, 3 and 1 (each within the scatter of the next).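

this assay now offers a first direct comparison at this position, on the nitrogen on an aromatic ring: a 1.2-fold lower number from compound 1 to compound 4 (0.09 log units; within the scatter). The pair shows that 2,4-dimethoxyphenyl and plain phenyl cannot be told apart here, even though the swap takes away 2 hydrogen-bond acceptors and goes from 10 heavy atoms to 6 in this group, so neither methoxy group is needed to keep this level of growth inhibition on this shared core. No measurement at hand explains this result.

From the compounds shown here alone, this is a single pair with one chain on the core, so it remains open whether the same swap would read the same way with another chain, such as a longer one. Going by these compounds, it also remains open whether a quite different group on the phenyl ring, such as an amine or a carboxylic acid, would move the number beyond the scatter, or whether this position tolerates nearly anything in this assay.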